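Trimming the pentan-3-yl group of compound 1

The source may hold more compounds than are shown below. What is called first, only, known or untested is meant among the compounds shown, and "the series" means these compounds.

Within the data shown here, in an in vitro ADME assay on microsomes from liver (Canis lupus familiaris) for metabolic stability (on this read-out higher numbers stand for fast clearance and lower numbers for slow clearance), compound 1 `CCC(CC)[C@@H]1C(=O)N[C@H](C2Cc3ccccc3C2)C(=O)N1[C@@H](C(=O)N1CCOCC1)c1ccc(C)nc1` gives 5 mL.min-1.g-1 and stands highest of the three numbers so far. Compound 2 `CCC(CC)[C@@H]1C(=O)N[C@H](C2Cc3ccccc3C2)C(=O)N1[C@@H](C(=O)N1CCOCC1)c1ccc(C)nc1C` gives 1 mL.min-1.g-1 and compound 3 `CCC(CC)[C@@H]1C(=O)N[C@H](C2Cc3ccccc3C2)C(=O)N1[C@@H](C(=O)N(C)C)c1ccc(C)nc1` gives 1 mL.min-1.g-1 on the same read-out, and both lie beyond the scatter from compound 1.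

Two measured steps start from compound 1. Methyl in place of hydrogen on an aromatic carbon gave a 5.0-fold lower number from compound 1 to compound 2 (0.70 log units; beyond the scatter) and dimethylamino in place of morpholin-4-yl on a carbonyl carbon gave a 5.0-fold lower number from compound 1 to compound 3 (0.70 log units; beyond the scatter) as the second modest step.

Compound 4 `CC[C@@H](C)[C@@H]1C(=O)N[C@H](C2Cc3ccccc3C2)C(=O)N1[C@@H](C(=O)N1CCOCC1)c1ccc(C)nc1` keeps both of those sites as in compound 1 and differs elsewhere: sec-butyl in place of pentan-3-yl on a saturated ring carbon is the whole change.

Among the measured compounds shown here, neither measured step touches this carbon, so the data hold no direct precedent for the change. Both steps were made at other sites and give only a rough idea of how far one change can move the number. The expected move in this assay is therefore small and stays within the scatter, with a 1.3-fold lower number from compound 1 to compound 4 (0.10 log units; within the scatter) as the estimated step. The estimate for compound 4 is 4 mL.min-1.g-1 with an expected range from 1.5 mL.min-1.g-1 to 10 mL.min-1.g-1 on this read-out.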

Compound 4, intrinsic clearance in microsomes: 2 mL.min-1.g-1
For compound 4 the middle estimate is 2.0-fold (0.30 log units) above the measured one; the measured number falls inside the stated range.
By their numbers in this assay, from the lowest: compounds 2, 3 and 4 (each within the scatter of the next); then compound 1.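

Replacing pentan-3-yl with sec-butyl on the saturated ring carbon gives a 2.5-fold lower number from compound 1 to compound 4 (0.40 log units; beyond the scatter) in this assay, the only step shown at this carbon, so the number responds to the group here as well as at the two sites changed in compound 2 and compound 3. Under the computed comparison, the group goes from 5 heavy atoms to 4, all carbon, with no ring, hydrogen-bond donor, hydrogen-bond acceptor or net charge on either side, so a change this limited is enough to pass the usual scatter in this series. Among these compounds, the single step ties together the loss of one carbon and the arrival of a defined stereocentre and cannot separate them, and no supporting measurement speaks to why the number moved.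

As far as these compounds go, it remains open how the read-out would follow isopropyl, ethyl or cyclopropyl on this carbon, or the opposite configuration at the sec-butyl stereocentre. Also open, from the compounds shown here alone, is whether sec-butyl combines with the extra aromatic methyl of compound 2 or the dimethylamino group of compound 3 in a way that adds to either of those single changes.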